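This account rests on a few compounds, and the source may have more. Where it says the series, first, only, none or still open, it means among the compounds named here.

Measured so far:

Compound 1 `CCN(CC)CCNc1nc(-c2ccc(NC(=O)Nc3ccc(Cl)cc3)cc2)nc2c(Cl)c(Cl)sc12`: 430 nM
Compound 2 `CCN(CC)CCNc1nc(-c2ccc(NC(=O)Nc3ccc(Cl)cc3)cc2)nc2ccsc12`: 150 nM
Compound 3 `CCN(CC)CCNc1nc(-c2ccc(NC(=O)Nc3ccccc3Cl)cc2)nc2c(Cl)c(Cl)sc12`: 550 nM

All three were tested in a functional assay on HT-29 cells (Homo sapiens) for cytotoxicity, read by MTT assay, with a stated time of 72 h; a lower number here means a stronger inhibitor, a higher number a weaker inhibitor. Compound 2 gives the lowest number of the three, and its gaps to compound 1 and to compound 3 both lie beyond the scatter. Compound 2 and compound 1 differ in their cores, and that difference is not broken down here. Compound 1 and compound 3 share a core and differ in one place: 2-chlorophenyl in place of 4-chlorophenyl on an amide-type nitrogen. This change gave a 1.3-fold higher number from compound 1 to compound 3 (0.11 log units; within the scatter), a step within the scatter, so the two numbers are not told apart.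

Compound 4 `CCN(CC)CCNc1nc(-c2ccc(NC(=O)Nc3ccccc3Cl)cc2)nc2ccsc12` has not yet been measured in this assay. It stands to compound 2 as compound 3 stands to compound 1: 2-chlorophenyl in place of 4-chlorophenyl on an amide-type nitrogen. The place of the change is the same, an amide-type nitrogen whose other neighbour is a carbonyl carbon, so this is the same change. Among the measured compounds shown here, because the one measured example gave a 1.3-fold higher number from compound 1 to compound 3 (0.11 log units; within the scatter), a similarly small step is expected here, a 1.3-fold higher number from compound 2 to compound 4 (0.10 log units; within the scatter). Compound 4 is therefore estimated at 190 nM, with the range 90 nM to 400 nM allowing for the usual scatter.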

Compound 4, half-maximal inhibitory concentration: 620 nM
Beside the measured number, compound 4's estimate is 3.3-fold (0.51 log units) below it, and the stated range ends below it.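

In this assay, putting 2-chlorophenyl in place of 4-chlorophenyl on the amide-type nitrogen gave a 4.1-fold higher number from compound 2 to compound 4 (0.62 log units; beyond the scatter), a step beyond the scatter on the core of compound 2. The size of this step therefore did not carry over from one core to the other, so a result from one core is a poor guide to the other here: the same change on two cores in this assay, a 1.3-fold higher number (0.11 log units; within the scatter) from compound 1 to compound 3 and a 4.1-fold higher number (0.62 log units; beyond the scatter) from compound 2 to compound 4, 3.2-fold (0.51 log units) apart, beyond the scatter of two such steps. These two pairs show that the core can matter, but they do not show which part of the core is responsible or why, and two pairs cannot set a rule for the whole series.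

As far as these compounds go, it remains open how the change would behave on a third core, and whether the same gap between cores would appear with another pair of groups, such as 2-fluorophenyl and 4-fluorophenyl or 2-methoxyphenyl and 4-methoxyphenyl. Also open, from the compounds shown here alone, is whether a carboxylic acid on that ring would follow either core's pattern.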